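From Hydroxy to Amino on the Aromatic Carbon

A few compounds are considered here, and "the series" means these few. Any claim that something is new, unique, unknown or untested is made for them only; others in the source may bear on it.

Compound 1 `Cc1cccc(C(=O)/C=C/c2ccc3c(c2)B(O)OC3)c1` gives 6700 nM in a functional assay on HCT-116 cells (Homo sapiens) for cytotoxicity, read by MTT assay, with a stated time of 48 h; on this read-out higher numbers stand for weaker inhibition and lower numbers for stronger inhibition.
Compound 2 `O=C(/C=C/c1ccc2c(c1)B(O)OC2)c1cccc(O)c1` gives 6500 nM in this assay.

Going by the values given here, compound 2 has the lowest of the two numbers measured so far, but its only neighbour is compound 1, and the step of a 1.0-fold lower number from compound 1 to compound 2 (0.01 log units; within the scatter) lies within the scatter, so the two compounds cannot be told apart on these data. That one step, hydroxy in place of methyl on an aromatic carbon, is the whole of what has been measured about changes at this carbon.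

Compound 3 `Nc1cccc(C(=O)/C=C/c2ccc3c(c2)B(O)OC3)c1` has not yet been measured. It differs from compound 2 by amino in place of hydroxy on an aromatic carbon. Among the compounds with values here, no measured step tests this exchange directly. Within the data shown here, the only step that touches the same carbon, a 1.0-fold lower number from compound 1 to compound 2 (0.01 log units; within the scatter), left the number essentially where it was, with two different groups there giving the same result. Among the measured compounds shown here, a third group at that carbon is therefore expected to give a similar number, with a wide range because a 1.0-fold lower number from compound 1 to compound 2 (0.01 log units; within the scatter) is the sole guide and the present exchange itself is untested. Compound 3 is expected to give about 6500 nM in this assay, within a range from 2800 nM to 15000 nM. That estimate corresponds to an expected step of no change at the digits printed from compound 2 to compound 3 (within the scatter).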

Compound 3, half-maximal inhibitory concentration: 4500 nM
Estimate against measurement, compound 3: 1.4-fold (0.16 log units) above; measured number inside the range.
By their numbers in this assay, from the lowest: compounds 3, 2 and 1 (each within the scatter of the next).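

With amino, this aromatic carbon has now carried three different groups, and in this assay the results still cannot be told apart. Exchanging hydroxy for amino gives a 1.4-fold lower number from compound 2 to compound 3 (0.16 log units; within the scatter) and exchanging methyl for amino gives a 1.5-fold lower number from compound 1 to compound 3 (0.17 log units; within the scatter), so neither new step stands out from the ordinary variation between repeated measurements. Going by these compounds alone, the earlier pair offered only one exchange at this carbon, whereas compound 1, compound 2 and compound 3 now provide three comparisons among methyl, hydroxy and amino, and none of them separates two compounds in this cell test. The data give no explanation for why these groups produce such similar numbers.

As far as these compounds go, whether a carboxylic acid, a nitrile or a longer chain such as propyl at this carbon would produce a step beyond the scatter remains open, so the limits of this flat stretch of results are not yet known. Also open, from the compounds shown here alone, is whether methyl, hydroxy and amino would remain indistinguishable if they sat on a different carbon of this six-membered ring or if the shared core were changed.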